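Shifting a methyl around the phenyl ring of a piperidine amide

The source may report more compounds than this note shows. Statements on the series, on what has been measured and on what is new or still open speak of the compounds shown alone.

Compound 2, `CC(=O)N1CCC(C(=O)N2CC[C@H](C(=O)N(C)Cc3cc(C(F)(F)F)cc(C(F)(F)F)c3)[C@@H](c3ccc(C)cc3)C2)CC1`, and compound 1, `CC(=O)N1CCC(C(=O)N2CC[C@@H](C(=O)N(C)Cc3cc(C(F)(F)F)cc(C(F)(F)F)c3)[C@H](c3ccccc3)C2)CC1`, share one core and differ only in the substituent on the phenyl ring. In an assay on IM-9 cells for displacement of a labelled ligand from Substance-P receptor (Homo sapiens), read by scintillation counting, with a stated time of 30 min (on this read-out lower numbers stand for stronger inhibition and higher numbers for weaker inhibition), compound 1 gives 0.098 nM. In this assay compound 2 gives 0.18 nM; of the two numbers shown, compound 2's is the one that the other lies closest to, and the gap between them is within the usual scatter, so the two cannot be told apart.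

Compound 3, `CC(=O)N1CCC(C(=O)N2CC[C@H](C(=O)N(C)Cc3cc(C(F)(F)F)cc(C(F)(F)F)c3)[C@@H](c3cccc(C)c3)C2)CC1`, has not yet been measured. It differs from compound 2 by 3-methylphenyl in place of 4-methylphenyl on a saturated ring carbon. The two measured compounds give no step of this kind, and no cause can be assigned to moving the methyl group from one ring position to another. The expectation is therefore a small step, if any, in this assay, leaning toward a somewhat higher number. Compound 3 is expected to give an estimated 0.3 nM, within a range of 0.08 nM to 1.2 nM, an expected step of a 1.7-fold higher number from compound 2 to compound 3 (0.22 log units; within the scatter).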

Compound 3, half-maximal inhibitory concentration: 0.14 nM
Beside the measured number, compound 3's estimate is 2.1-fold (0.33 log units) above it; measured number inside the range.
By their numbers in this assay, from the lowest: compounds 1, 3 and 2 (each within the scatter of the next).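

In this assay, exchanging 4-methylphenyl for 3-methylphenyl on the saturated ring carbon gives a 1.3-fold lower number from compound 2 to compound 3 (0.11 log units; within the scatter), so the two compounds cannot be told apart. Among these compounds, this is the first readable step at this position, and it shows that the read-out does not separate these two placements of the methyl group on the phenyl ring, even though the two groups have the same heavy atoms and differ only in how they are joined. Nothing available explains why the two compounds read alike.

Going by these compounds, it remains open whether the read-out would stay just as flat with a different group in place of the methyl, such as a methoxy group, a chlorine atom, a carboxylic acid or an amine, any of which would change what the phenyl ring carries rather than only where it carries it. This single pair also cannot say whether the same result would hold if the (1-acetylpiperidin-4-yl)carbonyl group or another part of the shared core were different.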